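This account rests on a few compounds, and the source may have more. Where it says the series, first, only, none or still open, it means among the compounds named here.

Compound 1 `CCCSc1nnc(COc2cc(C)c3c(C)cc(=O)oc3c2)o1`, compound 2 `CCCCCCSc1nnc(COc2cc(C)c3c(C)cc(=O)oc3c2)o1` and compound 3 `CCCS(=O)(=O)c1nnc(COc2cc(C)c3c(C)cc(=O)oc3c2)o1` share one core and differ only in a single side group. In a functional assay on MCF7 cells (Homo sapiens) for antiproliferative activity, read by MTT assay, with a stated time of 24 h (a higher number here means a weaker inhibitor, a lower number a stronger inhibitor), compound 1 gives only a limit of the assay, > 100000 nM. Compound 2 likewise gives a limit, > 100000 nM. Compound 3 also gives a limit, > 100000 nM, so where it truly stands cannot be fixed more closely. All three values sit at the limit of > 100000 nM in this assay, at which 3 of the 3 values shown sit. The steps a step that the two limits leave unreadable from compound 1 to compound 2, a step that the two limits leave unreadable from compound 1 to compound 3 and a step that the two limits leave unreadable from compound 2 to compound 3 are therefore unreadable. Compound 4 `Cc1cc(OCc2nnc(S(=O)(=O)Cc3cccc(F)c3)o2)cc2oc(=O)cc(C)c12` carries 3-fluorophenyl in place of ethyl on a saturated chain carbon bound to a sulfonyl sulfur. Among the measured compounds shown here, none of the measured steps shows whether such a change moves the value, so the step of a number no higher from compound 3 to compound 4 (the limit leaves the size open) is estimated as no more than the scatter. Compound 4 is expected to give 100000 nM, between 30000 nM and 300000 nM.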

Compound 4, half-maximal inhibitory concentration: 70400 nM
Estimate against measurement, compound 4: 1.4-fold (0.15 log units) above; the range from low to high includes it.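

Compound 4 is the only compound shown that gives a number in this assay rather than a limit, so a 3-fluorobenzyl at this place on the sulfonyl sulfur brings the value inside the measurable range. The change reads as an at least 1.4-fold lower number from compound 3 to compound 4 (0.15 log units; that floor lies within the scatter). Its true size stays open, as the other compounds all rest on one limit: the limit of > 100000 nM in this assay, at which 3 of the 4 values shown sit.

Open, on these data alone, is whether a plain benzyl would also give a number, which would separate the part played by the ring from that of the fluorine. Also open, as far as these compounds go, is how a 3-fluorobenzyl would read on the sulfanyl sulfur.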